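A Carbonyl Group in Place of Phenylsulfonyl

The source may report more compounds than this note shows. Statements on the series, on what has been measured and on what is new or still open speak of the compounds shown alone.

In an ADME assay on Karpas-1106P cells (Homo sapiens) for cytotoxicity (a higher number here means that more compound is needed for the effect, a lower number that less compound is needed), compound 3 (`Cc1ccc(S(=O)(=O)N[C@@H](CC(=O)NC(C)(C)C)C(=O)NCCNS(=O)(=O)c2ccccc2)cc1`) reads > 11100 nM as a limit. Compound 1 (`Cc1ccc(S(=O)(=O)N[C@@H](CC(=O)NC(C)(C)C)C(=O)NCCNC(=O)c2ccccc2F)cc1`) gives > 11100 nM as a limit. Compound 2 (`COc1cc(OC)cc(C(=O)NCCNC(=O)[C@H](CC(=O)NC(C)(C)C)NS(=O)(=O)c2ccc(C)cc2)c1`) gives > 11100 nM as a limit too. All three thus stand at one mark: the limit of > 11100 nM in this assay, at which 3 of the 3 values shown sit, in the data so far.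

Compound 4 (`Cc1ccc(S(=O)(=O)N[C@@H](CC(=O)NC(C)(C)C)C(=O)NCCNC(=O)c2cc(C)ccn2)cc1`) carries (4-methylpyridin-2-yl)carbonyl in place of phenylsulfonyl on an amine nitrogen. The closest precedents, a step that the two limits leave unreadable from compound 1 to compound 3 and a step that the two limits leave unreadable from compound 2 to compound 3, exchange a carbonyl group for phenylsulfonyl at that nitrogen, and neither has a readable size. Among the carbonyl groups, a step that the two limits leave unreadable from compound 1 to compound 2 is equally unreadable. No step beyond the scatter is therefore expected, and the estimated change is a step that the limit leaves unreadable from compound 3 to compound 4 in this assay with no direction to read. For compound 4 the estimate is 15000 nM, with an expected range of 6000 nM to 40000 nM and a limit the likeliest report.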

Compound 4, half-maximal effective concentration: > 11100 nM
Compound 4 gave a limit, no number (the forecaster's own chance of this, stated with the estimate: 90%); the middle value lies beyond the limit too.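

Compound 4 joins compounds 1, 2 and 3 at one limit, and none of its steps to them can be read: the limit of > 11100 nM in this assay, at which 4 of the 4 values shown sit.

None of these compounds gives a number in this assay, so whether any group on that amine nitrogen shifts the read-out stays open.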